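Fluoro for Methoxy at a Cytotoxicity Ceiling

The source may hold more compounds than are shown below. What is called first, only, known or untested is meant among the compounds shown, and "the series" means these compounds.

Compound 1, `O=c1[nH]c(=O)n(C2C[C@@H](O)[C@@H](CO)O2)nc1/C=C/Cl`, and compound 2, `COC(F)(F)Cc1nn(C2C[C@@H](O)[C@@H](CO)O2)c(=O)[nH]c1=O`, share the same core and have both been measured in a functional assay on Vero cells (Chlorocebus sabaeus) for cytotoxicity; on this read-out lower numbers stand for stronger inhibition and higher numbers for weaker inhibition. In this assay compound 1 reaches only the limit of the assay, > 500 ug/mL, and not a number. In this assay compound 2 likewise reaches only the limit, > 500 ug/mL. The step that the two limits leave unreadable from compound 1 to compound 2; what the two values share is the limit of > 500 ug/mL in this assay, at which 2 of the 2 values shown sit. Compound 3, `O=c1[nH]c(=O)n(C2C[C@@H](O)[C@@H](CO)O2)nc1CC(F)(F)F`, differs from compound 2 by fluoro in place of methoxy on a saturated chain carbon bound to two fluorine atoms and a saturated chain carbon. No measured step reads across this change, since the single step shown has no readable size. With both neighbours at the limit in this assay, compound 3 is expected to stay there too, and the step that the limit leaves unreadable from compound 2 to compound 3 is estimated as none beyond the scatter. For compound 3 in this assay the estimate is 600 ug/mL, with a range from 300 ug/mL to 1500 ug/mL.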

Compound 3, concentration for 50% inhibition: > 500 ug/mL
Compound 3: only a limit was reported; the forecaster's own chance of this, stated with the estimate: 85%; the middle value is on the limit's open side.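

No step can be read from compound 2 to compound 3 or from compound 1 to compound 3, since all three compounds sit at one limit: the limit of > 500 ug/mL in this assay, at which 3 of the 3 values shown sit.

In this assay the compounds shown leave open the actual value of each compound, and so whether any of these group changes alters it.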